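The source may report more compounds than this note shows. Statements on the series, on what has been measured and on what is new or still open speak of the compounds shown alone.

Compound 3 `O=S(=O)(NCCCNCc1ccccc1)c1cc(C(F)(F)F)cc(C(F)(F)F)c1` gives 13000 nM in a functional assay on BXPC-3 cells (Homo sapiens) for inhibition, read by MTT assay, with a stated time of 72 h (on this read-out higher numbers stand for weaker inhibition of growth and lower numbers for stronger inhibition of growth), the highest number among the three measured compounds. Compound 1 `CC(C)(C)c1ccc(CNCCCNS(=O)(=O)c2cc(C(F)(F)F)cc(C(F)(F)F)c2)cc1` gives 1400 nM and compound 2 `O=S(=O)(NCCCCNCc1ccc(Br)cc1)c1cc(C(F)(F)F)cc(C(F)(F)F)c1` gives 1700 nM. The step of a 9.3-fold higher number from compound 1 to compound 3 (0.97 log units; beyond the scatter) and the step of a 7.6-fold higher number from compound 2 to compound 3 (0.88 log units; beyond the scatter) both run from a substituted benzyl ring to the bare one, and both raise the number, although the second also alters the chain. Compound 4 `O=S(=O)(NCCCNCc1ccc(Cl)cc1)c1cc(C(F)(F)F)cc(C(F)(F)F)c1` differs from compound 3 by chloro in place of hydrogen on an aromatic carbon, which reverses the direction of those two steps. A lowering of the number in this assay is therefore expected, of about a 5.2-fold lower number from compound 3 to compound 4 (0.72 log units; beyond the scatter), kept somewhat below both measured steps. For compound 4 the estimated value in this assay is 2500 nM, with a range from 1100 nM to 6000 nM.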

Compound 4, concentration for 50% growth inhibition: 1600 nM
Compound 4: the middle estimate sits 1.6-fold (0.19 log units) above what was measured; the range from low to high includes it.
By their numbers in this assay, from the lowest: compounds 1, 4 and 2 (each within the scatter of the next); then compound 3.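

In this assay, chloro on this aromatic carbon gives an 8.1-fold lower number from compound 3 to compound 4 (0.91 log units; beyond the scatter), so a substituent here counts without any change to the chain. A single chlorine serves as well as tert-butyl, with a 1.1-fold higher number from compound 1 to compound 4 (0.06 log units; within the scatter), and the chain-altered bromo analogue gives no separation either, with a 1.1-fold lower number from compound 2 to compound 4 (0.03 log units; within the scatter). Nothing on hand explains why these different groups read alike. Open, from the compounds shown here alone, is whether methoxy, an amine or a carboxylic acid at this carbon would lower the number as chloro does, and whether 4-chlorobenzyl on the longer chain would match compound 2.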